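The source may hold more compounds than are shown below. What is called first, only, known or untested is meant among the compounds shown, and "the series" means these compounds.

Measured in an ADME assay on microsomes from liver (Mus musculus) for metabolic stability, read by LC-MS, with a stated time of 30 min, tested at 1 uM (a higher number here means that more of the compound is left, a lower number that less of the compound is left), so far
- compound 1 `CC(=O)N1CCN(C(=O)[C@@H]2CC[C@@H](C)N2C(=O)C2=C(C(C)C)N3C(=N[C@@](C)(c4ccc(Cl)cc4)[C@H]3c3ccc(Cl)cc3)S2)CC1` gives 13%
- compound 2 `CC[C@@H]1CC[C@@H](C(=O)N2CCOCC2)N1C(=O)C1=C(C(C)C)N2C(=N[C@@](C)(c3ccc(Cl)cc3)[C@H]2c2ccc(Cl)cc2)S1` gives 6%

In this assay compound 2 stands at 6%, within the usual scatter of compound 1 at 13%. Compound 3 `CC[C@@H]1CC[C@@H](C(=O)N2CCN(C(C)=O)[C@H](C)C2)N1C(=O)C1=C(C(C)C)N2C(=N[C@@](C)(c3ccc(Cl)cc3)[C@H]2c2ccc(Cl)cc2)S1` differs from compound 2 on a carbonyl carbon (a group of 10 heavy atoms (7 carbon, 2 nitrogen, 1 oxygen; one six-membered non-aromatic ring with 2 hetero atoms) in place of a group of 6 heavy atoms (4 carbon, 1 nitrogen, 1 oxygen; one six-membered non-aromatic ring with 2 hetero atoms), on a carbonyl carbon). Among the measured compounds shown here, no measured pair shows what this change does, so no shift beyond the scatter is expected. The expected a number 2 percentage points higher from compound 2 to compound 3 (within the scatter) therefore stays within the scatter. For compound 3 the estimated value in this assay is 8%, with a range of 2% to 20%.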

Compound 3, percent of the compound remaining: 59%
Compound 3: middle estimate off by 51 percentage points, on the low side; measured number outside the range, above it.
By their numbers in this assay, from the lowest: compounds 2 and 1 (each within the scatter of the next); then compound 3.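

In this assay, among the compounds shown here, the group on this carbonyl carbon proves able to move the read-out: putting the group of 10 heavy atoms in place of morpholin-4-yl gives a number 53 percentage points higher from compound 2 to compound 3 (beyond the scatter), and no earlier pair showed any such step. Nothing measured on these compounds explains the step.

Which part of the entering group accounts for it remains open, including its defined stereocentre. So does the outcome with other groups at this place, such as piperidin-1-yl or a carboxylic acid.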